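This account rests on a few compounds, and the source may have more. Where it says the series, first, only, none or still open, it means among the compounds named here.

In a functional assay on HEK293 cells for agonist activity at Glucose-dependent insulinotropic receptor (Homo sapiens), read by cAMP accumulation, with a stated time of 30 min (a higher number here means that more compound is needed for the effect, a lower number that less compound is needed), compound 1 `CC1(OC(=O)N2C[C@H]3COC[C@@H](C2)[C@@H]3Oc2ncnc(Nc3c(F)cccc3F)c2F)CC1` gives 13 nM, while compound 2 `COCC1(OC(=O)N2CC3COCC(C2)C3Oc2ncnc(Nc3ccc(C#N)cc3F)c2F)CC1` gives 49 nM, the higher of the two numbers recorded here, and that gap lies beyond the scatter of repeated measurements. Compound 3 `CCC1(OC(=O)N2CC3COCC(C2)C3Oc2ncnc(Nc3ccc(C#N)cc3F)c2F)CC1` differs from compound 2 in a single place: methyl in place of methoxy on a saturated chain carbon bound to a saturated ring carbon. Within the data shown here, no measured pair tracks this exact exchange, so only a modest step is expected, with no clear direction. Compound 3 is therefore estimated at 35 nM, within a range from 12 nM to 100 nM. The step this estimate implies, a 1.4-fold lower number from compound 2 to compound 3 (0.15 log units; within the scatter), is expected to sit near the usual scatter.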

Compound 3, half-maximal effective concentration: 6 nM
Estimate against measurement, compound 3: 5.8-fold (0.77 log units) above, and the stated range ends above it.
By their numbers in this assay, from the lowest: compound 3; then compound 1; then compound 2.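

In this assay, the exchange of methoxy for methyl on a saturated chain carbon bound to a saturated ring carbon gives an 8.2-fold lower number from compound 2 to compound 3 (0.91 log units; beyond the scatter), a step beyond the scatter. This position therefore responds clearly to a small change, here the shift from methoxymethyl to ethyl on the cyclopropyl group. Nothing available explains the size of this step. The compounds shown leave open how a longer chain such as propyl, a hydroxyl or an amine would read at this place, and whether this exchange would give a similar step on the core of compound 1.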